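The source may hold more compounds than are shown below. What is called first, only, known or untested is meant among the compounds shown, and "the series" means these compounds.

Measured compounds:
- compound 1 `COC1CN(C(=O)/C=C/c2ccncc2-c2ccc3ccccc3c2)C1`: in a functional assay on MCF7 cells (Homo sapiens) for inhibition, read by sulforhodamine B assay, with a stated time of 72 h (a higher number here means a weaker inhibitor of growth, a lower number a stronger inhibitor of growth), compound 1 gives > 10000 nM
- compound 2 `CNC(=O)/C=C/c1ccncc1-c1ccc2c(cnn2C)c1`: in this assay compound 2 gives > 10000 nM

Both values are limits of the assay rather than numbers. Compound 1 stands at the limit (the limit of > 10000 nM in this assay, at which 2 of the 2 values shown sit), so where it really lies is not known; it is only known to be a weak inhibitor of growth. Going by the values given here, compound 2 sits at the same limit, so no step between the two measured compounds can be sized, and nothing connects them by a single change.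

Compound 3 `COC(=O)/C=C/c1ccncc1-c1ccc2ccccc2c1` has not been measured. It differs from compound 1 in one place: methoxy in place of 3-methoxyazetidin-1-yl on a carbonyl carbon. The rest of the structure, the double-bonded chain and the shared core, is unchanged.

Among the compounds with values here, since the only numbers for this series are limits, there is no measured step to lean on. The change from compound 1 to compound 3 is expected to give a step that the limit leaves unreadable from compound 1 to compound 3 of no size beyond the scatter, in either direction. Compound 3 is therefore expected to come out at about 12000 nM, within the range 3000 nM to 40000 nM, and most likely the assay again reports only a limit for it.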

Compound 3, concentration for 50% growth inhibition: 8170 nM
Compound 3: middle estimate off by 1.5-fold (0.17 log units), on the high side; measured number inside the range.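

In this assay, going by these compounds alone, compound 3 gives 8170 nM, the first value in this short series that is a real number and not a limit, so a compound with this core and a group on this carbonyl carbon can register in the assay. Replacing the 3-methoxyazetidin-1-yl group with methoxy, which also removes the four-membered ring, gives an at least 1.2-fold lower number from compound 1 to compound 3 (0.08 log units; that floor lies within the scatter), so a real gain in growth inhibition can be neither claimed nor ruled out. The value for compound 1 is only a limit, so the true size of this step cannot be read, and the larger group could matter little or a great deal: the limit of > 10000 nM in this assay, at which 2 of the 3 values shown sit.

The compounds shown do not separate the effect of losing the ring from that of replacing the nitrogen on the carbonyl carbon with an oxygen. From the compounds shown here alone, it also remains open how a carboxylic acid, an ethyl ester or a simple dimethylamino group would behave at this same place on the unchanged core.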